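Isopropyl in place of phenyl on the ring nitrogen

The source may hold more compounds than are shown below. What is called first, only, known or untested is meant among the compounds shown, and "the series" means these compounds.

In a functional assay on A549 cells (Homo sapiens) for antiproliferative activity, read by MTT assay, with a stated time of 72 h (on this read-out higher numbers stand for weaker inhibition and lower numbers for stronger inhibition), compound 1 `COc1ncc(-c2ccc3c(c2)NC(=O)CO3)cc1NS(=O)(=O)c1ccc(F)cc1` gives 8070 nM, compound 2 `COc1ncc(-c2ccc3c(c2)N(C2CCCCC2)C(=O)CO3)cc1NS(=O)(=O)c1ccc(F)cc1` gives 24600 nM, and compound 3 `COc1ncc(-c2ccc3c(c2)N(c2ccccc2)C(=O)CO3)cc1NS(=O)(=O)c1ccc(F)cc1` gives 3490 nM, the lowest of the three numbers.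

Compound 4 `COc1ncc(-c2ccc3c(c2)N(C(C)C)C(=O)CO3)cc1NS(=O)(=O)c1ccc(F)cc1` carries isopropyl in place of phenyl on an amide-type nitrogen in a ring.

The closest measured change is phenyl in place of cyclohexyl, with a 7.0-fold lower number from compound 2 to compound 3 (0.85 log units; beyond the scatter). Hydrogen replaced by cyclohexyl gives a 3.0-fold higher number from compound 1 to compound 2 (0.48 log units; beyond the scatter), and hydrogen replaced by phenyl gives a 2.3-fold lower number from compound 1 to compound 3 (0.36 log units; beyond the scatter).

Loss of the phenyl is therefore expected to raise the number in this assay, though less than the gap between compound 2 and compound 3 shows. The expected step is a 3.4-fold higher number from compound 3 to compound 4 (0.54 log units; beyond the scatter).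

The estimate for compound 4 is 12000 nM, with a range of 5000 nM to 28000 nM.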

Compound 4, half-maximal inhibitory concentration: 4920 nM
The estimate for compound 4 lay 2.4-fold (0.39 log units) above the measured number; the whole stated range lies above it.
By their numbers in this assay, from the lowest: compounds 3, 4 and 1 (each within the scatter of the next, the first and the last beyond it); then compound 2.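

In this assay, isopropyl on the ring nitrogen stays level with phenyl (a 1.4-fold higher number from compound 3 to compound 4 (0.15 log units; within the scatter)) and with the amide hydrogen (a 1.6-fold lower number from compound 1 to compound 4 (0.21 log units; within the scatter)). Against cyclohexyl, the change is larger (a 5.0-fold lower number from compound 2 to compound 4 (0.70 log units; beyond the scatter)). Phenyl is therefore not required on this nitrogen: a group without a ring stays within the scatter of it, and the high number of compound 2 goes with cyclohexyl, not with every saturated carbon group.

On these data alone, whether methyl, a longer chain or a chain ending in an amine would track isopropyl or cyclohexyl remains open. No measured evidence accounts for these steps.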